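The compounds below may be only part of what the source reports. "The series", "measured", "known", "first", "only" and "open" are said of these compounds alone.

Three close relatives of one amidinourea-type core have been measured for agonist activity in a functional assay on HEK293T cells for agonist activity at histamine H2 receptor (Homo sapiens), read by beta-arrestin recruitment; a higher number here means that more compound is needed for the effect, a lower number that less compound is needed. Compound 1 `CCCNC(=O)/N=C(\N)NCCCc1sc(N)nc1C` gives 170 nM. Compound 2 `Cc1nc(N)sc1CCCN/C(N)=N/C(=O)NCC(C)CC1CCCCC1`, which carries a cyclohexylmethyl in place of hydrogen on the chain, gives 302 nM. Compound 3 `Cc1ccc(CC(C)CNC(=O)/N=C(\N)NCCCc2sc(N)nc2C)cc1`, carrying a 4-methylbenzyl at the same place, gives 132 nM. Compound 3 thus shows the lowest number of the three, but its distance to compound 1 is within the scatter, so no order between those two can be claimed; the step of a 2.3-fold lower number from compound 2 to compound 3 (0.36 log units; beyond the scatter) is the only one beyond the scatter, and it is modest.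

Compound 4 `Cc1nc(N)sc1CCCN/C(N)=N/C(=O)NCC(C)CCCc1ccccc1` is the next member. Relative to compound 3 the change is phenethyl in place of 4-methylphenyl on a saturated chain carbon, three bonds along the chain from an amide-type nitrogen. The measured steps that bear on it are a 2.3-fold lower number from compound 2 to compound 3 (0.36 log units; beyond the scatter), where a saturated ring gave way to an aromatic one at this same place, and a 1.3-fold lower number from compound 1 to compound 3 (0.11 log units; within the scatter), where the whole 4-methylbenzyl arm was added. Both are small, and the aromatic ring is kept in compound 4 while only the linker grows, so no step beyond the scatter is expected in this assay. Compound 4 is therefore estimated at 180 nM, with a range of 90 nM to 360 nM, which means an expected step of a 1.4-fold higher number from compound 3 to compound 4 (0.13 log units; within the scatter).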

Compound 4, half-maximal effective concentration: 2510 nM
Estimate against measurement, compound 4: 14-fold (1.14 log units) below; the measured number lies above the stated range.
By their numbers in this assay, from the lowest: compounds 3, 1 and 2 (each within the scatter of the next, the first and the last beyond it); then compound 4.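

In this assay, this position on the saturated chain carbon proves far less forgiving than the first compounds suggested: the cyclohexylmethyl and 4-methylbenzyl arms each stayed within the scatter of the unsubstituted parent, whereas the 3-phenylpropyl arm gives a 15-fold higher number from compound 1 to compound 4 (1.17 log units; beyond the scatter) and so moves well beyond it. The aromatic ring alone does not secure the lower number, since phenethyl and 4-methylphenyl each hold one six-membered aromatic ring of carbon only and no hydrogen-bond donors or acceptors, yet that change gives a 19-fold higher number from compound 3 to compound 4 (1.28 log units; beyond the scatter), and phenethyl in place of cyclohexyl likewise gives an 8.3-fold higher number from compound 2 to compound 4 (0.92 log units; beyond the scatter) and reverses the modest gain that the aromatic ring seemed to bring. No measurement at hand offers a reason for this sharp rise.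

The compounds shown leave open whether the rise comes from the longer link to the ring or from the loss of the ring's methyl, which an unsubstituted benzyl arm or a 4-methylphenethyl arm would separate. They also leave open whether a still longer chain such as 4-phenylbutyl, or an amine or carboxylic acid on the arm, would raise the number further or bring it back.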